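The source may hold more compounds than are shown below. What is called first, only, known or untested is meant among the compounds shown, and "the series" means these compounds.

Compound 1, `CC(C)(C)c1ccc(C(=O)N2CCC3(CC2)C(=O)N(CC(=O)NCCCCCNS(C)(=O)=O)CN3c2ccccc2)cc1`, gives 5500 nM in an assay on HEK293 cells for displacement of a labelled ligand from NPC1-like intracellular cholesterol transporter 1 (Homo sapiens); on this read-out higher numbers stand for weaker inhibition and lower numbers for stronger inhibition.
Compound 2, `CC(C)(C)c1ccc(C(=O)N2CCC3(CC2)C(=O)N(CC(=O)NCNS(C)(=O)=O)CN3c2ccccc2)cc1`, gives 3200 nM in this assay.
Compound 3, `CCOC(=O)C1CCN(C(=O)CN2CN(c3ccccc3)C3(CCN(C(=O)c4ccc(C(C)(C)C)cc4)CC3)C2=O)CC1`, gives 3100 nM in this assay.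

The three compounds share one core and differ only in the group attached to the carbonyl carbon of the side chain. Compound 3 carries the lowest number of the three, but its gaps to the others are small: a 1.8-fold lower number from compound 1 to compound 3 (0.25 log units; within the scatter) and a 1.0-fold lower number from compound 2 to compound 3 (0.01 log units; within the scatter), so on these numbers the three compounds cannot be told apart.

Compound 4, `CC(C)(C)c1ccc(C(=O)N2CCC3(CC2)C(=O)N(CC(=O)N2CCNCC2)CN3c2ccccc2)cc1`, takes the next step from compound 3: piperazin-1-yl in place of 4-(ethoxycarbonyl)piperidin-1-yl on a carbonyl carbon. Among the compounds with values here, no measured step tests this exact exchange. What the measured steps do show is that swapping the whole group on that carbonyl carbon, from an open chain ending in a methanesulfonamide to the ester-bearing piperidine, moved the numbers little, as seen in a 1.8-fold lower number from compound 1 to compound 3 (0.25 log units; within the scatter) and a 1.0-fold lower number from compound 2 to compound 3 (0.01 log units; within the scatter). Another swap at the same position, to a ring with a free amine hydrogen, may therefore be expected to stay within the scatter too, though this rests on only three compounds.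

The expected step is a 1.1-fold higher number from compound 3 to compound 4 (0.05 log units; within the scatter). Compound 4 is estimated to give 3500 nM in this assay, with a likely range from 1500 nM to 9000 nM.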

Compound 4, half-maximal inhibitory concentration: 22000 nM
The estimate for compound 4 lay 6.3-fold (0.80 log units) below the measured number; the whole stated range lies below it.
By their numbers in this assay, from the lowest: compounds 3, 2 and 1 (each within the scatter of the next); then compound 4.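

Within the data shown here, the group on this carbonyl carbon is less free to change than the earlier compounds suggested: in this assay, piperazin-1-yl gives a higher number than each of the three other groups, with steps beyond the scatter (a 7.1-fold higher number from compound 3 to compound 4 (0.85 log units; beyond the scatter)), (a 6.9-fold higher number from compound 2 to compound 4 (0.84 log units; beyond the scatter)) and (a 4.0-fold higher number from compound 1 to compound 4 (0.60 log units; beyond the scatter)). A ring on this carbon is tolerated in one case and not in the other, so having a six-membered ring there does not settle the outcome, and what that ring carries counts. Compounds 1 and 2 each have an open chain with amide hydrogens and stay within the scatter of compound 3, so a hydrogen-bond donor on the group does not by itself go with a higher number, and no measurement shown here accounts for the shift.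

Compound 4 both loses the ethoxycarbonyl group and gains a ring nitrogen bearing a hydrogen, and these two changes cannot be told apart on the compounds shown. A plain piperidin-1-yl would test the loss of the ester alone, while a piperazine with a methyl group on that nitrogen, or a piperidine carrying a carboxylic acid, would test what the ring's end group contributes.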